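The source may report more compounds than this note shows. Statements on the series, on what has been measured and on what is new or still open speak of the compounds shown alone.

In an in vitro functional assay on CHO-CREluc cells for antagonist activity at growth hormone secretagogue receptor type 1 (Homo sapiens), read by a luciferase reporter, with a stated time of 4 h (a lower number here means a stronger inhibitor, a higher number a weaker inhibitor), two compounds have been measured:
compound 1 `CN1CCN(CC(=O)NC2(c3ccc(Cl)c(Cl)c3)C(=O)Nc3cc(Cl)ccc32)CC1` gives 111 nM;
compound 2 `CN1CCN(CC(=O)NC2(c3ccc(Cl)cc3)C(=O)Nc3cc(Cl)cc(Cl)c32)CC1` gives 72 nM.

Compound 2 has the smaller of the two numbers, yet compound 1 lies within the usual scatter of it, so neither can be called the stronger inhibitor. Compound 3 `CN1CCN(CC(=O)NC2(c3ccc(Cl)cc3)C(=O)Nc3cc(Cl)ccc32)CC1` is not yet measured. It arises from compound 2 by hydrogen in place of chloro on an aromatic carbon. Among the measured compounds shown here, no measured pair shows this change, so its effect is unknown. A mild weakening, or no step beyond the scatter, is expected here as a 1.8-fold higher number from compound 2 to compound 3 (0.26 log units; within the scatter). For compound 3 the estimated value is 130 nM, with a range from 50 nM to 350 nM.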

Compound 3, half-maximal inhibitory concentration: 140 nM
The estimate for compound 3 lay 1.1-fold (0.03 log units) below the measured number; the range from low to high includes it.
By their numbers in this assay, from the lowest: compounds 2, 1 and 3 (each within the scatter of the next).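

Hydrogen in place of the chloro ortho to a fused ring gives a 1.9-fold higher number from compound 2 to compound 3 (0.29 log units; within the scatter), so these compounds do not show that this chloro matters for inhibition. Hydrogen in place of a chloro elsewhere on the molecule gives a 1.3-fold higher number from compound 1 to compound 3 (0.10 log units; within the scatter), so that chloro is not shown to matter either. No measurement here bears on why these steps are this size.

Still open, on these data alone, is whether a different group at this position, such as a methoxy group or an amine, would move the number beyond the scatter.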